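Swapping diethylamino for ethoxy on the shared core

The source may report more compounds than this note shows. Statements on the series, on what has been measured and on what is new or still open speak of the compounds shown alone.

Values in an ADME assay on cells (Fibroblast, Homo sapiens) for antiproliferative activity, with a stated time of 48 h; a lower number here means a stronger inhibitor, a higher number a weaker inhibitor:
- Compound 1 `CCN(CC)c1ccc(-c2ccc(C(C)=O)cc2)nn1`: > 25000 nM, a limit of the assay and not a number
- Compound 2 `CCN(CC)c1ccc(-c2ccc(C(=O)OC)cc2)nn1`: 100 nM
- Compound 3 `CCOC(=O)c1ccc(-c2ccc(N(CC)CC)nn2)cc1`: 3000 nM

Compound 3, at 3000 nM, has the higher of the two true numbers in this assay. The step that separates it from its nearest neighbour is a 30-fold higher number from compound 2 to compound 3 (1.48 log units; beyond the scatter).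

Compound 4 `CCOC(=O)c1ccc(-c2ccc(OCC)nn2)cc1` carries ethoxy in place of diethylamino on an aromatic carbon. Every measured step changes the group on the carbonyl and leaves diethylamino untouched, so none gives a direct guide to this change. They do show that one small change can move the number a long way: an at least 250-fold lower number from compound 1 to compound 2 (2.39 log units; beyond the scatter), and an at least 8.3-fold lower number from compound 1 to compound 3 (0.92 log units; beyond the scatter).

Only compound 2 sits lower than compound 3, as a 30-fold higher number from compound 2 to compound 3 (1.48 log units; beyond the scatter) shows, so a modest rise is expected, with much doubt. The expected change is a 1.7-fold higher number from compound 3 to compound 4 (0.22 log units; within the scatter). For compound 4 the estimate is 5000 nM, with an expected range from 800 nM to 25000 nM.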

Compound 4, half-maximal inhibitory concentration: > 25000 nM
Compound 4 gave a limit, no number; the forecaster's own chance of this, stated with the estimate: 25%; middle value at least 5.0-fold (0.69 log units) away from the limit.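

Among the compounds shown here, until now every step changed the group on the carbonyl, so this is the first look at the group on the aromatic carbon, and in this assay that group matters as well: ethoxy in place of diethylamino gives an at least 8.3-fold higher number from compound 3 to compound 4 (0.92 log units; beyond the scatter). Here the group on the carbonyl stays ethoxy, so the whole step belongs to the one swap on the shared core. Compound 4 gives > 25000 nM, which is a limit of the assay and not a number, so the step's full size stays unknown: the limit of > 25000 nM in this assay, at which 2 of the 4 values shown sit.

As far as these compounds go, whether a smaller amine such as dimethylamino, or a ring amine such as pyrrolidine, would hold the number near that of compound 3 remains open. So does how the same swap would play out with methoxy on the carbonyl, as in compound 2.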